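The source may report more compounds than this note shows. Statements on the series, on what has been measured and on what is new or still open speak of the compounds shown alone.

Compound 1 `Cc1cc(C#N)cc(C)c1Oc1nc(Nc2ccc(C#N)cc2)ncc1/C=C/C(N)=O`: > 243 nM
Compound 2 `Cc1cc(C#N)cc(C)c1Oc1nc(Nc2ccc(C#N)cc2)ncc1/C=C/C(=O)NCCOCCO`: > 200 nM
Compound 3 `Cc1cc(C#N)cc(C)c1Oc1nc(Nc2ccc(C#N)cc2)ncc1/C=C/C(=O)NC1CCN(C(=O)C(F)(F)F)CC1`: > 170 nM

All three compounds share the core of compound 1 and were tested in an ADME assay on TZM cells (Homo sapiens) for cytotoxicity, with a stated time of 1 days; on this read-out higher numbers stand for lower toxicity in this test and lower numbers for higher toxicity in this test. Compound 2 gives only a limit there, > 200 nM. The other two values shown are also limits, so compound 2 stands at a limit among limits, and no order among the three can be read. The step from compound 2 to the unmeasured compound 4 `Cc1cc(C#N)cc(C)c1Oc1nc(Nc2ccc(C#N)cc2)ncc1/C=C/C(=O)N1CCN(S(C)(=O)=O)CC1` is 4-(methylsulfonyl)piperazin-1-yl in place of (2-(2-hydroxyethoxy)ethyl)amino on a carbonyl carbon. The measured steps that bear on this change all replace hydrogen or the 2-(2-hydroxyethoxy)ethyl group on the amide-type nitrogen with another group, and none of them is readable: a step that the two limits leave unreadable from compound 1 to compound 2, a step that the two limits leave unreadable from compound 1 to compound 3 and a step that the two limits leave unreadable from compound 2 to compound 3. Each of these pairs sits at two limits, so the size of the step is not known in any case, and no direction can be taken from them. For compound 4 the expectation is therefore no step beyond the scatter, a number no higher from compound 2 to compound 4 (the limit leaves the size open), with a good chance that this assay again reports only a limit. Compound 4 is expected to give about 200 nM in this assay, between 100 nM and 400 nM.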

Compound 4, half-maximal cytotoxic concentration: > 179 nM
Compound 4 was reported as a limit; the forecaster's own chance of this, stated with the estimate: 85%; the middle value does not contradict the limit.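

In this assay compound 4 gives only a limit, > 179 nM. Compound 1 and compound 2 also stand at limits, so neither step to compound 4 can be read. The compounds shown leave open where the half-maximal cytotoxic concentration of any of them lies, and whether 4-(methylsulfonyl)piperazin-1-yl in place of (2-(2-hydroxyethoxy)ethyl)amino changes it at all.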